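This account rests on a few compounds, and the source may have more. Where it says the series, first, only, none or still open, it means among the compounds named here.

Measured so far:
compound 1 `C[C@H](N)C(=O)NS(=O)(=O)OC[C@H]1OC[C@@H](n2cnc3c(N)ncnc32)[C@H](O)[C@@H]1O`: 300 nM
compound 2 `CCC[C@H](N)C(=O)NS(=O)(=O)OC[C@H]1O[C@@H](n2cnc3c(N)ncnc32)[C@H](O)[C@@H]1O`: 4700 nM

In a functional assay on PBMC cells (Homo sapiens) for inhibition (on this read-out higher numbers stand for weaker inhibition and lower numbers for stronger inhibition), compound 1 has the lowest of the two numbers; compound 2 sits at a higher number, and the gap is beyond the scatter. Going by the values given here, compound 2 differs from compound 1 in more than one place, so the pair gives no clean step. Compound 3 `CC(C)C[C@H](N)C(=O)NS(=O)(=O)OC[C@H]1OC[C@@H](n2cnc3c(N)ncnc32)[C@H](O)[C@@H]1O` differs from compound 1 in one place: isopropyl in place of hydrogen on a saturated chain carbon, two bonds along the chain from an amine nitrogen and a carbonyl carbon. Among the compounds with values here, no measured pair shows this change. A modest step of uncertain direction is expected, a 2.0-fold higher number from compound 1 to compound 3 (0.30 log units; within the scatter). Compound 3 is therefore estimated at 600 nM, with a range from 100 nM to 4000 nM.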

Compound 3, half-maximal inhibitory concentration: 1000 nM
The estimate for compound 3 lay 1.7-fold (0.22 log units) below the measured number; the range from low to high includes it.
By their numbers in this assay, from the lowest: compound 1; then compound 3; then compound 2.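

In this assay, isopropyl in place of hydrogen on a saturated chain carbon, two bonds along the chain from an amine nitrogen and a carbonyl carbon, gives a 3.3-fold higher number from compound 1 to compound 3 (0.52 log units; beyond the scatter) and so weakens inhibition. Going by these compounds alone, this is the first one-place step, and it shows that the position responds to this change, with a modest loss and inhibition still measurable. Nothing available bears on the cause of this step.

Open, going by these compounds, is whether a carboxylic acid, a primary amine or a phenyl ring at the end of this chain would follow the same direction. A single step also leaves open how inhibition varies with chain length or branching at this position.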